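A Chloro-for-Trifluoromethyl Swap on the Aryl Ring

A few compounds are considered here, and "the series" means these few. Any claim that something is new, unique, unknown or untested is made for them only; others in the source may bear on it.

The three measured compounds share one core and differ in the aryl groups around it. Compound 1 `Nc1scc(-c2cccc(C(F)(F)F)c2)c1C(=O)c1ccccc1` gives 83% in a functional assay on CHO cells for agonist activity at adenosine receptor A1 (Homo sapiens), read by fluorescence and ERK phosphorylation, with stated times of 30 min and 1.5 h, tested at 3 uM; on this read-out higher numbers stand for a stronger effect at the one concentration tested and lower numbers for a weaker effect. Compound 2 `Nc1scc(-c2ccc3ccccc3c2)c1C(=O)c1ccccc1` gives 55% in this assay. Compound 3 `Nc1scc(-c2cccc(C(F)(F)F)c2)c1C(=O)c1ccc(Cl)cc1` gives 64% in this assay. Compound 3 thus stands second highest of the three numbers: its nearest neighbour is compound 2, whose value lies within the usual scatter of it, while compound 1 sits beyond the scatter above it. Going by the values given here, the only single-site step among the measured compounds, a chloro in place of hydrogen on an aromatic carbon, is a number 19 percentage points lower from compound 1 to compound 3 (beyond the scatter).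

Compound 4 `Nc1scc(-c2cccc(Cl)c2)c1C(=O)c1ccc(Cl)cc1` is the unmeasured one. It differs from compound 3 in one place: chloro in place of trifluoromethyl on an aromatic carbon, on an aromatic carbon of a six-membered aromatic ring of carbon only, meta to a large group. No measured pair here shows this swap, so the size of the step from compound 3 cannot be drawn from any shown step; the one step that is shown concerns a different ring and a different change. With nothing bearing directly on it, the step to compound 4 is expected to be a number 4 percentage points lower from compound 3 to compound 4 (within the scatter), that is no change beyond the scatter. Compound 4 is therefore estimated at 60% in this assay, within a range from 35% to 85%.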

Compound 4, a percentage reported as activity, at one concentration (the size of the read-out at that concentration, not a potency): 58%
Estimate against measurement, compound 4: 2 percentage points above, and the stated range covers the measured number.
By their numbers in this assay, from the lowest: compounds 2, 4 and 3 (each within the scatter of the next); then compound 1.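

Chloro in place of trifluoromethyl, on an aromatic carbon of a six-membered aromatic ring of carbon only and meta to a large group, is in this assay a step of a number 6 percentage points lower from compound 3 to compound 4 (within the scatter). Going by these compounds alone, this is the first view of a change at this position: the only earlier single-site step, a number 19 percentage points lower from compound 1 to compound 3 (beyond the scatter), lay on the other aryl group and was beyond the scatter, whereas here a group of 4 heavy atoms gives way to one of 1 heavy atom with no change beyond the scatter. With chloro already on the other aryl group, trifluoromethyl at this position is thus not needed to keep the read-out within the scatter of compound 3, and no measurement shown here accounts for this result.

The compounds shown leave open whether the same swap would read alike with hydrogen instead of chloro on the other aryl group, and how a methoxy group, an amine or a carboxylic acid would read at this position. On these data alone, since the read-out gives the size of the effect at one concentration, any difference in potency between compound 3 and compound 4 also remains open.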